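The source may hold more compounds than are shown below. What is called first, only, known or untested is meant among the compounds shown, and "the series" means these compounds.

Measured in an ADME assay on J774.A1 cells (Mus musculus) for cytotoxicity, read by MTT assay, with a stated time of 72 h; a higher number here means that more compound is tolerated, a lower number that less compound is tolerated:
- compound 1 `CC(C)c1ccc(C(Nc2ccc(C3(C)NC(=O)c4ccccc4N3)cc2)c2nnnn2C(C)(C)C)cc1`: > 400000 nM, a limit
- compound 2 `CC1(c2ccc(NC(c3ccc(Cl)cc3)c3nnnn3C(C)(C)C)cc2)NC(=O)c2ccccc2N1`: > 400000 nM, a limit
- compound 3 `CC1(c2ccc(NC(c3ccncc3)c3nnnn3C(C)(C)C)cc2)NC(=O)c2ccccc2N1`: "not determined" (no result reported)

Among the compounds with values here, compound 3 has no number of its own, and the only readings nearby are the limit of > 400000 nM in this assay, at which 2 of the 3 values shown sit. The change to compound 4 `COc1ccc(C(Nc2ccc(C3(C)NC(=O)c4ccccc4N3)cc2)c2nnnn2C(C)(C)C)cc1` is 4-methoxyphenyl in place of pyridin-4-yl on a saturated chain carbon bound to an aromatic carbon and a nitrogen on an aromatic ring. Within the data shown here, the one measured step, a step that the two limits leave unreadable from compound 1 to compound 2, has no readable size, so it offers no measure for this change. Among the measured compounds shown here, no step from compound 3 can be sized in this assay. Like compound 1 and compound 2, compound 4 has an aromatic ring of carbon only at that place, so a reading at the same limit is expected, given (the limit of > 400000 nM in this assay, at which 2 of the 3 values shown sit). Compound 4 is estimated at 450000 nM, with an expected range of 200000 nM to 800000 nM.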

Compound 4, half-maximal cytotoxic concentration: > 400000 nM
Compound 4: a limit, no number; the forecaster's own chance of this, stated with the estimate: 85%; the middle value lies beyond the limit too.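

No step among compound 1, compound 2 and compound 4 can be read in this assay, as all three values are limits: the limit of > 400000 nM in this assay, at which 3 of the 4 values shown sit.

Going by these compounds, whether any of these ring changes shifts tolerance at all remains open.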